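The source may hold more compounds than are shown below. What is called first, only, known or untested is meant among the compounds shown, and "the series" means these compounds.

Three compounds share one core and differ only in the ring carried on a saturated chain carbon bound to an aromatic carbon and a saturated chain carbon. In a functional assay on cardiac atrium for agonist activity at histamine H2 receptor (Cavia porcellus) (on this read-out lower numbers stand for lower potency and higher numbers for higher potency (the scale is a negative logarithm)), compound 1 `N=C(NCCCc1c[nH]cn1)NCCC(c1cccc(F)c1)c1ccccn1` gives 7.88, compound 2 `N=C(NCCCc1c[nH]cn1)NCCC(c1cc(F)cc(F)c1)c1ccccn1` gives 8.05, and compound 3 `N=C(NCCCc1c[nH]cn1)NCCC(c1ccc(Cl)c(Cl)c1)c1ccccn1` gives 8.19, the highest of the three numbers. The step of a number 0.31 log units higher from compound 1 to compound 3 (beyond the scatter) lies beyond the scatter, whereas the steps of a number 0.17 log units higher from compound 1 to compound 2 (within the scatter) and a number 0.14 log units higher from compound 2 to compound 3 (within the scatter) do not, so the three rings tried so far give numbers close to one another. Compound 4 `N=C(NCCCc1c[nH]cn1)NCCC(c1ccccn1)c1cccs1` carries thiophen-2-yl in place of 3,4-dichlorophenyl on a saturated chain carbon bound to an aromatic carbon and a saturated chain carbon. The steps from compound 1 and from compound 2 to compound 3 bear on this change, since each swaps one ring for another at the same place, and both were small. Thiophen-2-yl departs further from the rings measured so far than those rings did from one another, so a small loss is expected rather than none, giving an estimated step of a number 0.39 log units lower from compound 3 to compound 4 (beyond the scatter) in this assay. Compound 4 is therefore expected to give 7.8, within 7.3 to 8.3.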

Compound 4, negative logarithm of the half-maximal effective concentration: 7.16
Compound 4: middle estimate off by 0.64 log units, on the high side; the whole stated range lies above it.
By their numbers in this assay, from the lowest: compound 4; then compounds 1, 2 and 3 (each within the scatter of the next, the first and the last beyond it).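

The three earlier rings suggested that this position, a saturated chain carbon bound to an aromatic carbon and a saturated chain carbon, accepts a change of ring with little effect. In this assay, however, thiophen-2-yl gives a number 1.03 log units lower from compound 3 to compound 4 (beyond the scatter) and a number 0.89 log units lower from compound 2 to compound 4 (beyond the scatter) and a number 0.72 log units lower from compound 1 to compound 4 (beyond the scatter) in this small series. The tolerance seen among the three halogen-bearing six-membered rings therefore does not extend to this five-membered ring with its one hetero atom, and nothing available here explains the drop.

Still open, from the compounds shown here alone, is whether the loss goes with the smaller ring, with the sulfur, or with the absence of halogen. A furan-2-yl ring or an unsubstituted phenyl ring at this place would help to separate these possibilities.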